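Homologation at the aryl ether of a bromomethyl chromone

A few compounds are considered here, and "the series" means these few. Any claim that something is new, unique, unknown or untested is made for them only; others in the source may bear on it.

Compound 1 `Cc1cc(=O)oc2cc(SC3CCOC3=O)ccc12`: in a functional assay on DU-145 cells (Homo sapiens) for antiproliferative activity, read by sulforhodamine B assay, with a stated time of 72 h (on this read-out lower numbers stand for stronger inhibition of growth and higher numbers for weaker inhibition of growth), compound 1 gives > 36100 nM, a limit of the assay.
Compound 2 `COc1cc(CSc2ccc3c(C)cc(=O)oc3c2)cc(OC)c1`: in this assay compound 2 gives > 29200 nM, a limit.
Compound 3 `CCc1cc(=O)c2ccc(OC)c(CBr)c2o1`: in this assay compound 3 gives > 33600 nM, a limit.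

Compound 3 stands where every value shown stands: at a limit, with no number resolved for any of the three. The step to compound 4 `CCc1cc(=O)c2ccc(OCC(C)C)c(CBr)c2o1` is isopropyl in place of hydrogen on a saturated chain carbon bound to an oxygen on an aromatic ring. No measured step between any two of these compounds exists to set a scale, so in this assay no step beyond the scatter is expected from compound 3 to compound 4, and a further limit is the likeliest outcome. Compound 4 is expected to give 40000 nM, within 10000 nM to 120000 nM, an expected step that the limit leaves unreadable from compound 3 to compound 4.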

Compound 4, concentration for 50% growth inhibition: > 29400 nM
Compound 4 gave a limit, no number; the forecaster's own chance of this, stated with the estimate: 70%; the middle value lies beyond the limit too.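

Among the compounds shown here, compound 3 and compound 4 both sit at limits in this assay, so no step from methoxy to isobutoxy can be read. The compounds shown leave open whether this change affects growth inhibition at all.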